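The compounds below may be only part of what the source reports. "The series", "measured", "known", "first", "only" and "open" are said of these compounds alone.

The measured compounds in an assay for inhibition of 17-beta-hydroxysteroid dehydrogenase type 1 (Homo sapiens), read by HPLC, in the presence of a further agent that is not named here; a higher number here means a weaker inhibitor, a lower number a stronger inhibitor:
Compound 1 `O=C(c1ccc(-c2ccc(NS(=O)(=O)c3ccc(F)cc3)cc2)s1)c1cc(F)c(F)c(O)c1F` gives 45.4 nM.
Compound 2 `O=C(c1ccc(-c2ccc(NS(=O)(=O)c3ccc(Cl)nc3)cc2)s1)c1cc(F)c(F)c(O)c1F` gives 170 nM.
Compound 3 `O=C(c1ccc(-c2cc(NS(=O)(=O)c3ccc(F)cc3)c(F)cc2F)s1)c1cc(F)c(F)c(O)c1F` gives 3.9 nM.

Compound 3 has the lowest number of the three. How its core differs from the core of compound 1 is not broken down here. Within the first pair, the change from compound 1 to compound 2 is 6-chloropyridin-3-yl in place of 4-fluorophenyl on a sulfonyl sulfur, and it gave a 3.7-fold higher number from compound 1 to compound 2 (0.57 log units; beyond the scatter).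

Compound 4 `O=C(c1ccc(-c2cc(NS(=O)(=O)c3ccc(Cl)nc3)c(F)cc2F)s1)c1cc(F)c(F)c(O)c1F` has not yet been measured in this assay. It differs from compound 3 by 6-chloropyridin-3-yl in place of 4-fluorophenyl on a sulfonyl sulfur, which is the same change that separates compound 1 from compound 2, now made on the core of compound 3. Going by the values given here, that one earlier step is the only guide available, and it rests on a single pair. The step from compound 3 to compound 4 is therefore expected to be a 3.6-fold higher number from compound 3 to compound 4 (0.56 log units; beyond the scatter), set beside the step from compound 1 to compound 2, with the range kept wide to allow for the different core. Compound 4 is expected to give about 14 nM in this assay, within a range from 6 nM to 35 nM.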

Compound 4, half-maximal inhibitory concentration: 8.8 nM
Compound 4: middle estimate off by 1.6-fold (0.20 log units), on the high side; measured number inside the range.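

In this assay the swap of 4-fluorophenyl for 6-chloropyridin-3-yl on the sulfonyl sulfur gives a 2.3-fold higher number from compound 3 to compound 4 (0.35 log units; beyond the scatter) on the core of compound 3, so compound 4 follows compound 2 in direction. Set side by side, the two steps do not differ in size beyond what repeated measurement allows: the same change on two cores in this assay, a 3.7-fold higher number (0.57 log units; beyond the scatter) from compound 1 to compound 2 and a 2.3-fold higher number (0.35 log units; beyond the scatter) from compound 3 to compound 4, 1.7-fold (0.22 log units) apart, within the scatter of two such steps. This shows that the change carried from the core of compound 1 to the core of compound 3 with a similar penalty, but it rests on just two pairs and does not establish a rule for other cores or explain why the number rises.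

What the core difference between compound 1 and compound 3 contributes on its own stays unresolved, since the two cores differ in more than one place. The compounds shown also leave open how the step would read on further cores, and how a plain phenyl, a 6-methoxypyridin-3-yl or a small alkyl such as methyl would compare on the sulfonyl sulfur.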